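Sulfo for Hydroxy: One Change Seen Twice

This account rests on a few compounds, and the source may have more. Where it says the series, first, only, none or still open, it means among the compounds named here.

Compound 1 `COc1ccc(/C=C2\CN(C(=O)CCSCCS(=O)(=O)O)C/C(=C\c3ccc(OC)cc3)C2=O)cc1` gives 91700 nM in a functional assay on HL-60 cells (Homo sapiens) for cytotoxicity, read by trypan blue exclusion, with a stated time of 48 h; a higher number here means that more compound is tolerated, a lower number that less compound is tolerated.
Compound 2 `COc1ccc(/C=C2\CN(C(=O)CCSCCO)C/C(=C\c3ccc(OC)cc3)C2=O)cc1` gives 2670 nM in this assay.
Compound 3 `O=C1/C(=C/c2ccc([N+](=O)[O-])cc2)CN(C(=O)CCSCCO)C/C1=C\c1ccc([N+](=O)[O-])cc1` gives 390 nM in this assay.

Compound 1 and compound 2 share one core and differ only by sulfo in place of hydroxy on a saturated chain carbon, two bonds along the chain from a sulfur. That change made the step of a 34-fold higher number from compound 2 to compound 1 (1.54 log units; beyond the scatter), so much more of compound 1 than of compound 2 is tolerated by the cells.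

Compound 3 sits on a different core; the difference between the core of compound 3 and the core of compound 2 is not broken down here. Of the three measured compounds, compound 3 has the lowest number in this assay.

Compound 4 `O=C1/C(=C/c2ccc([N+](=O)[O-])cc2)CN(C(=O)CCSCCS(=O)(=O)O)C/C1=C\c1ccc([N+](=O)[O-])cc1` is compound 3 with sulfo in place of hydroxy on a saturated chain carbon, two bonds along the chain from a sulfur. The place of this change is worded exactly as for the earlier pair, so it is the same change on a second core. The expectation for compound 4 rests on the measured step from compound 2 to compound 1, and a step of similar size is expected: a 33-fold higher number from compound 3 to compound 4 (1.52 log units; beyond the scatter). For compound 4, a value of about 13000 nM is expected in this assay, most likely between 3500 nM and 50000 nM.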

Compound 4, half-maximal cytotoxic concentration: 4730 nM
Beside the measured number, compound 4's estimate is 2.7-fold (0.44 log units) above it; low and high end bracket the measured number.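

On the second core, the same swap gives a 12-fold higher number from compound 3 to compound 4 (1.08 log units; beyond the scatter) in this assay. The direction therefore carries over: on both cores, cells tolerate more of the sulfo compound than of its hydroxy partner. The size does not carry over unchanged, since the two steps differ by more than repeated measurements would explain: the same change on two cores in this assay, a 34-fold higher number (1.54 log units; beyond the scatter) from compound 2 to compound 1 and a 12-fold higher number (1.08 log units; beyond the scatter) from compound 3 to compound 4, 2.8-fold (0.45 log units) apart, beyond the scatter of two such steps Two cores are only two cases, however, so this does not show that the swap would raise the number on every core in the series, and nothing here explains why the step differs in size between these two cores.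

The compounds shown leave open whether a similar rise would follow from placing a carboxylic acid or an amine on the chain instead of the sulfo group, or from carrying the sulfo group on a longer chain. They also leave open whether a third core would give a step closer to the larger or the smaller of these two.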